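The source may hold more compounds than are shown below. What is called first, only, known or untested is meant among the compounds shown, and "the series" means these compounds.

Among the measured compounds shown here, the three compounds measured so far share one core and differ only in the aryl group that hangs from a saturated ring carbon. Compound 1 `CCOC(=O)C12C(=O)OCC=C1COC2c1ccccc1F` gives 22100 nM in a functional assay on HeLa cells (Homo sapiens) for cytotoxicity, read by MTT assay; a higher number here means a weaker inhibitor, a lower number a stronger inhibitor. Compound 2 `CCOC(=O)C12C(=O)OCC=C1COC2c1ccc(F)cc1` gives 22900 nM in this assay, and compound 3 `CCOC(=O)C12C(=O)OCC=C1COC2c1cc(OC)cc(OC)c1` gives 16000 nM. For the measured compounds named here, the one step between compounds that differ in a single place is a 1.0-fold higher number from compound 1 to compound 2 (0.02 log units; within the scatter), so moving the fluoro around the aryl ring leaves the number where it was. Compound 2 stands within the scatter of both compound 1 and compound 3; its number is not separated from either of theirs.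

Compound 4 `CCOC(=O)C12C(=O)OCC=C1COC2c1ccc(N(C)C)cc1` has not yet been measured. It differs from compound 2 by dimethylamino in place of fluoro on an aromatic carbon. Going by the values given here, no measured step exchanges one aryl substituent for another of a different kind; the only step that bears on the change, from compound 1 to compound 2, moved a fluoro and stayed within the scatter, and compound 3 with its two methoxy groups also sits within the scatter of compound 2. On that basis a step of a 1.1-fold lower number from compound 2 to compound 4 (0.06 log units; within the scatter) is expected, that is, none beyond the scatter. Compound 4 is therefore estimated at 20000 nM in this assay, with a range from 8000 nM to 50000 nM.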

Compound 4, half-maximal inhibitory concentration: 23400 nM
Beside the measured number, compound 4's estimate is 1.2-fold (0.07 log units) below it, and the stated range covers the measured number.
By their numbers in this assay, from the lowest: compounds 3, 1, 2 and 4 (each within the scatter of the next).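

In this assay, among the compounds shown here, the step of a 1.0-fold higher number from compound 2 to compound 4 (0.01 log units; within the scatter) is the first one that exchanges an aryl substituent for one of a different kind, rather than moving the same fluoro around the ring, and it stays within the scatter. Dimethylamino brings 3 heavy atoms and 1 hydrogen-bond acceptor where fluoro had 1 heavy atom and 0 hydrogen-bond acceptors, so on an aromatic carbon para to a large group, this difference in size and acceptor count comes with no separable change in the number for this pair. No measurement in hand accounts for this insensitivity, so the result stands as an observation without an explanation.

The compounds shown leave open whether any substituent at this position can separate a compound from the others, for instance a carboxylic acid, a primary amine or a longer alkoxy chain in place of the fluoro of compound 2. From the compounds shown here alone, they also leave open what happens away from the aryl group, since the ethyl ester stays the same throughout and an amide or a free carboxylic acid there remains untested in this set.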